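The source may hold more compounds than are shown below. What is called first, only, known or untested is meant among the compounds shown, and "the series" means these compounds.

Compound 1 `CCC(=O)c1ccc(NCc2cncn2Cc2ccc(-c3ccccc3)cc2)cc1-c1ccccc1` serves as the reference for this comparison. In a toxicity assay on NIH3T3 cells (Mus musculus) for cytotoxicity, read by resazurin assay (on this read-out lower numbers stand for an effect already at smaller amounts and higher numbers for an effect only at larger amounts of compound), compound 1 gives only a limit of the assay, > 10000 nM. Compound 2 `COC(=O)c1ccc(NCc2cncn2Cc2ccccc2Br)cc1-c1ccccc1` gives a number in this assay, 10000 nM. Compound 3 `Cc1cccc(-c2cccc(NCc3cncn3Cc3ccccc3)c2)c1` gives only a limit in this assay, > 1000 nM. The two limits sit at different levels, one at the limit of > 1000 nM in this assay, at which 1 of the 3 values shown sits, and one at the limit of > 10000 nM in this assay, at which 1 of the 3 values shown sits, so no ordering among the three can be read from them. Among the compounds with values here, no step between two measured compounds is available, so the change itself has not been measured directly. Compound 4 `c1ccc(-c2ccc(Cn3cncc3CNc3ccc(N4CCCC4)c(-c4ccccc4)c3)cc2)cc1` is not yet measured; it differs from compound 1 by pyrrolidin-1-yl in place of propanoyl on an aromatic carbon. For this change the expected step is a number no higher from compound 1 to compound 4 (the limit leaves the size open), nothing beyond the usual scatter in this assay. Compound 4 is expected at 10000 nM, between 4000 nM and 25000 nM, and most likely again reported only as a limit.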

Compound 4, half-maximal effective concentration: > 1000 nM
Compound 4: only a limit was reported (the forecaster's own chance of this, stated with the estimate: 70%); the middle value lies beyond the limit too.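

Compound 1 and compound 4 are both reported only as limits, so no step can be read for pyrrolidin-1-yl in place of propanoyl. The compounds shown leave open whether this exchange shifts the read-out at all, and in which direction.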